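Cytotoxicity notes: oxamide series, cyclohexyl to 1-phenylethyl

This account rests on a few compounds, and the source may have more. Where it says the series, first, only, none or still open, it means among the compounds named here.

Measured compounds:
- compound 1 `COC(=O)c1nc2c(cnn2-c2ccccc2)c(=O)[nH]1`: 40000 nM
- compound 2 `N#Cc1cnn(-c2ccccc2)c1NC(=O)C(=O)Nc1c(C#N)cnn1-c1ccccc1`: 100000 nM
- compound 3 `N#Cc1cnn(-c2ccccc2)c1NC(=O)C(=O)NC1CCCCC1`: 80000 nM

In an ADME assay on THP-1 cells (Homo sapiens) for cytotoxicity (a lower number here means that less compound is needed, a higher number that more compound is needed for the effect), compound 3 gives 80000 nM, which sits between the numbers of compound 2 and compound 1; both gaps lie within the scatter, so the three compounds are not separated by this read-out.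

Compound 4 `CC(NC(=O)C(=O)Nc1c(C#N)cnn1-c1ccccc1)c1ccccc1` is not yet measured. It differs from compound 3 by 1-phenylethyl in place of cyclohexyl on an amide-type nitrogen. Within the data shown here, no step between measured compounds isolates such a change. With all three measured numbers lying within the scatter of one another, no direction is indicated, and compound 4 is expected to stay close to compound 3. The step from compound 3 to compound 4 in this assay is estimated at no change at the digits printed from compound 3 to compound 4 (within the scatter), none beyond the scatter. Compound 4 is expected at 80000 nM, in the range 30000 nM to 200000 nM.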

Compound 4, half-maximal effective concentration: 500000 nM
The estimate for compound 4 lay 6.3-fold (0.80 log units) below the measured number, outside the stated range (above it).
By their numbers in this assay, from the lowest: compounds 1, 3 and 2 (each within the scatter of the next, the first and the last beyond it); then compound 4.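

In this assay, among these compounds, the group on the amide-type nitrogen does separate compounds: 1-phenylethyl in place of cyclohexyl gives a 6.3-fold higher number from compound 3 to compound 4 (0.80 log units; beyond the scatter), the only step so far that isolates a single change and lies beyond the scatter. This one step therefore shows that cytotoxicity read-outs in the oxamide series can respond to this position, with more compound needed for the effect. No measurement at hand bears on the reason for the step. Open, from the compounds shown here alone, is whether benzyl on the same nitrogen would keep the higher number, and whether a carboxylic acid or an amine there would shift it.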